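The source may report more compounds than this note shows. Statements on the series, on what has been measured and on what is new or still open speak of the compounds shown alone.

Compound 1, `COc1ccc2[nH]c(C(=O)N3CC(=O)N(Cc4ccccc4)[C@@H](CCc4ccccc4)C3)cc2c1`, was tested in an ADME assay on Vero cells (Chlorocebus sabaeus) for cytotoxicity, with a stated time of 7 days (a lower number here means that less compound is tolerated, a higher number that more compound is tolerated), where compound 1 gives > 30000 nM; this figure is a limit of the assay rather than a measured number. A second compound, compound 2, `COc1ccc2[nH]c(C(=O)N3CC(=O)N(Cc4cccc(OC)n4)[C@@H](Cc4ccccc4)C3)cc2c1`, is also in hand, and in this assay compound 2 gives > 30000 nM, again a limit and not a number. Among the measured compounds shown here, compound 1 therefore stands at the limit of > 30000 nM in this assay, at which 2 of the 2 values shown sit, so no number places it above or below compound 2, and no step between measured compounds can be drawn from these two.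

The next compound is compound 3, `COc1ccc2[nH]c(C(=O)N3CC(=O)N(Cc4ccccc4)[C@@H](CN4CC5CCCC5C4)C3)cc2c1`. The change from compound 1 to compound 3 is a group of 8 heavy atoms (7 carbon, 1 nitrogen; one five-membered non-aromatic ring of carbon only, one five-membered non-aromatic ring with 1 hetero atom) in place of a group of 7 heavy atoms (7 carbon; one six-membered aromatic ring of carbon only), on a saturated chain carbon bound to a saturated ring carbon. For the measured compounds named here, with no measured step to lean on, the expectation rests on the two limits alone: since compound 1 gives > 30000 nM at the limit, no shift beyond the usual scatter is expected from compound 1 to compound 3 in this assay, and the estimated step is a number no higher from compound 1 to compound 3 (the limit leaves the size open). For compound 3 the expected reading in this assay is 30000 nM, within a range from 12000 nM to 60000 nM, and another limit is the likelier outcome.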

Compound 3, half-maximal cytotoxic concentration: 10600 nM
Compound 3: the middle estimate sits 2.8-fold (0.45 log units) above what was measured, outside the stated range (below it).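

In this assay, among the compounds shown here, compound 3 is the only compound here that gives a number rather than a limit, and the change on the saturated chain carbon bound to a saturated ring carbon brings an at least 2.8-fold lower number from compound 1 to compound 3 (0.45 log units; beyond the scatter). For the compounds shown here, the earlier compounds could show no such shift, as neither reading could be placed against the other: the limit of > 30000 nM in this assay, at which 2 of the 3 values shown sit. This place therefore matters in this assay: with benzyl gone and the group holding one five-membered ring of carbon only and one five-membered ring with a nitrogen in its stead, less compound is tolerated, and the full size of the step remains unknown, as the reading for compound 1 is a limit.

The compounds shown leave open whether the shift goes with the nitrogen and its hydrogen-bond acceptor, with the two rings, or with the loss of the benzyl group, as this single pair changes all of these at once. A dimethylamino group, a cyclopentyl ring or a carboxylic acid at this place would begin to separate these possibilities.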